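The compounds below may be only part of what the source reports. "The series", "measured", "known", "first", "only" and "open" are said of these compounds alone.

In an assay on PMNL cells for inhibition of Polyunsaturated fatty acid 5-lipoxygenase (Homo sapiens), read by HPLC, with stated times of 5 min and 15 min (a higher number here means a weaker inhibitor, a lower number a stronger inhibitor), three compounds built on one shared core have been measured. Compound 1 `COc1cc(/C=C/C(=O)OCCc2cccc(F)c2)cc(OC)c1O` gives 230 nM, compound 2 `COc1cc(/C=C/C(=O)OCCc2ccccc2F)cc(OC)c1O` gives 240 nM, and compound 3 `COc1cc(/C=C/C(=O)OCCc2cccc(C)c2)cc(OC)c1O` gives 200 nM. Compound 3 carries the lowest of the three numbers, but the steps of a 1.2-fold lower number from compound 1 to compound 3 (0.06 log units; within the scatter) and a 1.2-fold lower number from compound 2 to compound 3 (0.08 log units; within the scatter) both lie within the scatter, so no order among the three can be drawn. The next compound is compound 4 `COc1cccc(CCOC(=O)/C=C/c2cc(OC)c(O)c(OC)c2)c1`, and the change from compound 3 is methoxy in place of methyl on an aromatic carbon. The measured step that bears most directly on it is the exchange of one small aromatic substituent for another, a 1.2-fold lower number from compound 1 to compound 3 (0.06 log units; within the scatter), which stayed within the scatter; the other placing of the fluoro, a 1.0-fold higher number from compound 1 to compound 2 (0.02 log units; within the scatter), was equally uneventful. On that basis the expected outcome in this assay is a 1.1-fold higher number from compound 3 to compound 4 (0.02 log units; within the scatter), with no change beyond the scatter. Compound 4 is therefore estimated at 210 nM, in a range from 110 nM to 400 nM.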

Compound 4, half-maximal inhibitory concentration: 210 nM
Estimate against measurement, compound 4: no gap at the digits printed; the range from low to high includes it.
By their numbers in this assay, from the lowest: compounds 3, 4, 1 and 2 (each within the scatter of the next).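

Methoxy in place of methyl on this aromatic carbon brings in one more heavy atom and a hydrogen-bond acceptor, yet in this assay the outcome is a 1.1-fold higher number from compound 3 to compound 4 (0.02 log units; within the scatter) and no more. The comparisons with the fluoro compounds read the same way, with a 1.1-fold lower number from compound 1 to compound 4 (0.04 log units; within the scatter) for methoxy in place of fluoro and a 1.1-fold lower number from compound 2 to compound 4 (0.06 log units; within the scatter) for 3-methoxyphenyl in place of 2-fluorophenyl, so an oxygen-linked group joins fluoro and methyl here with no step beyond the scatter. Nothing measured alongside these numbers accounts for this. The compounds shown leave open whether an amine or a carboxylic acid on this ring would give a step beyond the scatter. They also leave open what a longer chain between the ring and the oxygen next to the carbonyl would do.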